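The source may hold more compounds than are shown below. What is called first, only, known or untested is meant among the compounds shown, and "the series" means these compounds.

Among the compounds with values here, compound 3 `COC(=O)COc1cc(CNc2nc3c(N)ncnc3n2[C@@H]2O[C@H](CO)[C@@H](O)[C@H]2O)ccc1-c1ccccc1` gives 3300 nM in an assay on COS-7 cells for inhibition of sodium/nucleoside cotransporter 2 (Homo sapiens), read by scintillation counting (on this read-out lower numbers stand for stronger inhibition and higher numbers for weaker inhibition), the highest of the three numbers so far. Compound 1 `COc1cc(CNc2nc3c(N)ncnc3n2[C@@H]2O[C@H](CO)[C@@H](O)[C@H]2O)ccc1-c1ccccc1` gives 1300 nM in this assay, and compound 2 `Nc1ncnc2c1nc(NCc1ccc(-c3ccccc3)cc1O)n2[C@@H]1O[C@H](CO)[C@@H](O)[C@H]1O` gives 1300 nM there; both stand the same distance from compound 3, each beyond the scatter. Within the data shown here, the one measured step touching this position is a 2.5-fold higher number from compound 1 to compound 3 (0.40 log units; beyond the scatter), a modest loss when a group is put on the chain carbon bound to the ring oxygen. Compound 4 `Nc1ncnc2c1nc(NCc1ccc(-c3ccccc3)c(OCCCCCO)c1)n2[C@@H]1O[C@H](CO)[C@@H](O)[C@H]1O` differs from compound 3 by 4-hydroxybutyl in place of methoxycarbonyl on a saturated chain carbon bound to an oxygen on an aromatic ring. Among the measured compounds shown here, no measured pair shows a hydroxyalkyl chain at this place, so the step to compound 4 has only indirect support: the group that arrives with compound 3 is removed, and a longer chain takes its place. The expected outcome is a 1.3-fold lower number from compound 3 to compound 4 (0.12 log units; within the scatter), a partial return toward the numbers of compound 1 and compound 2 rather than a further rise, with wide uncertainty. Compound 4 is therefore estimated at 2500 nM in this assay, with a range from 900 nM to 7000 nM.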

Compound 4, half-maximal inhibitory concentration: 1600 nM
Compound 4: the middle estimate sits 1.6-fold (0.19 log units) above what was measured, and the stated range covers the measured number.
By their numbers in this assay, from the lowest: compounds 1, 2 and 4 (each within the scatter of the next); then compound 3.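

At this position the carbon can carry a long chain: with 4-hydroxybutyl in place of methoxycarbonyl on a saturated chain carbon bound to an oxygen on an aromatic ring, the result is a 2.1-fold lower number from compound 3 to compound 4 (0.31 log units; beyond the scatter). Set against hydrogen at the same carbon, the same chain gives a 1.2-fold higher number from compound 1 to compound 4 (0.09 log units; within the scatter), so on this read-out compound 4 cannot be told apart from compound 1, and the cost seen with methoxycarbonyl does not extend to every group added here. No supporting data explain either step.

From the compounds shown here alone, a chain of another length, or one ending in an amine or a carboxylic acid instead of the hydroxyl, remains open. Going by these compounds, it is also open whether the cost seen with methoxycarbonyl comes from that group as a whole or from some part of it.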